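From acetyl to fluoro on a shared core

A few compounds are considered here, and "the series" means these few. Any claim that something is new, unique, unknown or untested is made for them only; others in the source may bear on it.

Compound 1 `CC(=O)c1ccc(/N=C2\C=C(OCc3cn(S(=O)(=O)c4ccc(C)cc4)nn3)C(=O)c3ccccc32)cc1`: 15800 nM
Compound 2 `Cc1ccc(S(=O)(=O)n2cc(COC3=C/C(=N\c4ccc(I)cc4)c4ccccc4C3=O)nn2)cc1`: > 16300 nM, a limit of the assay

For the measured compounds named here, in a functional assay on NCI-H460 cells (Homo sapiens) for cytotoxicity, read by MTT assay, with a stated time of 72 h (a lower number here means a stronger inhibitor, a higher number a weaker inhibitor), compound 1 gives 15800 nM, the only actual number so far. Compound 2 stands at the limit of > 16300 nM in this assay, at which 1 of the 2 values shown sits, and that is a limit, not a number. Still unmeasured is compound 3 `Cc1ccc(S(=O)(=O)n2cc(COC3=C/C(=N\c4ccc(F)cc4)c4ccccc4C3=O)nn2)cc1`, whose change from compound 1 is fluoro in place of acetyl on an aromatic carbon. Going by the values given here, the one measured step that bears on it also removes the acetyl: an at least 1.0-fold higher number from compound 1 to compound 2 (0.01 log units; that floor lies within the scatter). On that evidence, no shift beyond the scatter is expected, and the estimated change is a 1.1-fold lower number from compound 1 to compound 3 (0.05 log units; within the scatter). For compound 3 the expected value is 14000 nM, with an estimated range of 6000 nM to 21000 nM.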

Compound 3, half-maximal inhibitory concentration: 7360 nM
Estimate against measurement, compound 3: 1.9-fold (0.28 log units) above; the range from low to high includes it.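

In this assay, for the compounds shown here, this position, para to a large group, does respond to the group placed on it: fluoro in place of acetyl gives a 2.1-fold lower number from compound 1 to compound 3 (0.33 log units; beyond the scatter), the first step here beyond the scatter. Fluoro in place of iodo gives an at least 2.2-fold lower number from compound 2 to compound 3 (0.34 log units; beyond the scatter), so fluoro stands apart from both other groups. That second step rests on compound 2, whose value is a limit and not a number: the limit of > 16300 nM in this assay, at which 1 of the 3 values shown sits.

As far as these compounds go, what an amine or a carboxylic acid on this aromatic carbon would give stays open. So does whether any group here brings the number well below that of compound 3.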